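The source may report more compounds than this note shows. Statements on the series, on what has been measured and on what is new or still open speak of the compounds shown alone.

Working notes on the triazole-carboxamide series.

Compound 1 `Cc1c(C(=O)Nc2ccc(Oc3ccnc4[nH]ccc34)c(F)c2)nnn1-c1ccc(F)cc1` gives 120 nM in a functional assay on HT-29 cells (Homo sapiens) for cytotoxicity, read by MTT assay, with a stated time of 72 h; a higher number here means a weaker inhibitor, a lower number a stronger inhibitor. Compound 2 `Cc1c(C(=O)Nc2ccc(Oc3ccnc4[nH]ccc34)c(F)c2)nnn1-c1ccc(F)c(F)c1` carries one more fluorine on the outer ring, and in this assay compound 2 gives 610 nM. The change fluoro in place of hydrogen on an aromatic carbon produces a 5.1-fold higher number from compound 1 to compound 2 (0.71 log units; beyond the scatter).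

Compound 3 `Cc1c(C(=O)Nc2ccc(Oc3ccnc4[nH]ccc34)cc2)nnn1-c1ccccc1` lacks the fluorine on the central ring and on the outer ring; how its core differs from that of compound 1 is not broken down here. In this assay compound 3 gives 350 nM, which compared with compound 2 lies within the scatter and compared with compound 1 is the higher number.

Compound 4 `Cc1c(C(=O)Nc2ccc(Oc3ccnc4[nH]ccc34)cc2)nnn1-c1ccccc1F` is not yet measured. It differs from compound 3 by fluoro in place of hydrogen on an aromatic carbon. This is the same kind of change as that from compound 1 to compound 2, but the surroundings differ: in compound 4 the fluoro sits ortho to a large group, whereas in compound 2 it sits ortho to a fluoro group and meta to a large group.

For the measured compounds named here, the step expected from compound 3 to compound 4 in this assay is a 1.7-fold higher number from compound 3 to compound 4 (0.23 log units; within the scatter), a smaller weakening than the one seen, because a 5.1-fold higher number from compound 1 to compound 2 (0.71 log units; beyond the scatter) was measured at a different place on the ring and only one such step is available. Compound 4 is therefore estimated at 600 nM, with a likely range from 250 nM to 1500 nM.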

Compound 4, half-maximal inhibitory concentration: 360 nM
Compound 4: the middle estimate sits 1.7-fold (0.22 log units) above what was measured; the range from low to high includes it.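

In this assay, the change from phenyl to 2-fluorophenyl gives a 1.0-fold higher number from compound 3 to compound 4 (0.01 log units; within the scatter), so on this core the added fluoro leaves the number within the scatter. The same kind of change therefore does not carry over with the same size from one core to the other in this series: the same change on two cores in this assay, a 5.1-fold higher number (0.71 log units; beyond the scatter) from compound 1 to compound 2 and a 1.0-fold higher number (0.01 log units; within the scatter) from compound 3 to compound 4, 4.9-fold (0.69 log units) apart, beyond the scatter of two such steps This rests on a single pair of steps in which the fluoro also sits at a different place on the outer ring, so the data do not show whether the core, the place or both account for the gap, and they give no rule for any other core.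

The compounds shown leave open whether a fluoro at other places on the outer ring of compound 3 would give a step like the one seen on the core of compound 1. They also leave open how a group other than fluoro, such as chloro, methoxy or an amine, would read ortho to a large group.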